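Changing the pendant aryl ring from compound 3 to compound 4

The source may hold more compounds than are shown below. What is called first, only, known or untested is meant among the compounds shown, and "the series" means these compounds.

Compound 1, `COc1cc(-n2cnc3ccc(-c4ccccc4)cc32)cc(OC)c1OC`, gives 3060 nM in a functional assay on A549 cells (Homo sapiens) for antiproliferative activity, read by MTT assay, with a stated time of 72 h; a lower number here means a stronger inhibitor, a higher number a weaker inhibitor.
Compound 2, `COc1cc(-n2cnc3ccc(-c4ccc(Cl)cc4Cl)cc32)cc(OC)c1OC`, is recorded in this assay as the limit > 10000 nM.
Compound 3, `COc1cc(-n2cnc3ccc(-c4ccc(C)cc4F)cc32)cc(OC)c1OC`, is recorded in this assay as the limit > 10000 nM.

Compound 3 therefore stands at the ceiling of what this assay reports rather than at a number, and it shares that position with one other compound: the limit of > 10000 nM in this assay, at which 2 of the 3 values shown sit. For the measured compounds named here, the only numeric value in the set belongs to compound 1, which carries a plain phenyl group.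

Compound 4, `COc1cc(-n2cnc3ccc(-c4ccc(C(C)=O)cc4)cc32)cc(OC)c1OC`, differs from compound 3 in one place: 4-acetylphenyl in place of 2-fluoro-4-methylphenyl on an aromatic carbon.

Going by the values given here, two measured steps bear on this change. Both departures from phenyl led away from a readable number: an at least 3.2-fold higher number from compound 1 to compound 2 (0.51 log units; beyond the scatter), and an at least 3.2-fold higher number from compound 1 to compound 3 (0.51 log units; beyond the scatter). Between the two substituted analogues the comparison is uninformative: a step that the two limits leave unreadable from compound 2 to compound 3. The 4-acetylphenyl group of compound 4 is a third, different substitution pattern, so the data allow no confident direction; the limits in this assay make a weaker result as plausible as a recovery toward compound 1.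

Compound 4 is expected to give 6000 nM in this assay, within 1800 nM to 20000 nM. The estimated step is an at least 1.6-fold lower number from compound 3 to compound 4 (0.22 log units; that floor lies within the scatter), a step that cannot be read against a limit.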

Compound 4, half-maximal inhibitory concentration: 2510 nM
Estimate against measurement, compound 4: 2.4-fold (0.38 log units) above, within the range that was stated.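

The 4-acetylphenyl group shows that a substituent on the pendant ring does not by itself push the compound to the limit in this assay, as the substituted ring stays level with the plain phenyl: a 1.2-fold lower number from compound 1 to compound 4 (0.09 log units; within the scatter). The substitution pattern therefore matters, and compound 4 separates clearly from both substituted analogues: an at least 3.9-fold lower number from compound 3 to compound 4 (0.60 log units; beyond the scatter), and an at least 3.9-fold lower number from compound 2 to compound 4 (0.60 log units; beyond the scatter). Compound 2 and compound 3 remain limits rather than numbers, so these two steps give only floors for the true differences: the limit of > 10000 nM in this assay, at which 2 of the 4 values shown sit.

The step between compound 2 and compound 3 still cannot be read, and the compounds shown do not separate the effect of the acetyl group from that of the halogens in 2,4-dichlorophenyl and 2-fluoro-4-methylphenyl. From the compounds shown here alone, it also remains open whether a readable number would survive with an amine, a carboxylic acid or a longer chain in place of the acetyl, or whether any such group would move the result beyond the level of compound 1 and compound 4.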